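This account rests on a few compounds, and the source may have more. Where it says the series, first, only, none or still open, it means among the compounds named here.

Of the compounds shown here, three built on a shared core have been measured in a functional assay (Homo sapiens), tested at 1 uM; on this read-out higher numbers stand for a weaker effect at the one concentration tested and lower numbers for a stronger effect. Compound 1 `O=C(/C=C/c1ccccc1)N1CCc2c(Cl)c(O)c(O)c(Cl)c2C1` gives 83%, compound 2 `O=C(CCCc1ccc(F)cn1)N1CCc2c(Cl)c(O)c(O)c(Cl)c2C1` gives 89%, and compound 3 `O=C(CCCc1ccc(C(F)(F)F)cn1)N1CCc2c(Cl)c(O)c(O)c(Cl)c2C1` gives 72%. Compound 2 stands highest of the three numbers; compound 1 lies nearest to it, within the usual scatter, and compound 3 lies furthest from it. Going by the values given here, the only single-point step measured so far runs from compound 2 to compound 3, where a trifluoromethyl takes the place of a fluoro on an aromatic carbon, and it brings a number 17 percentage points lower from compound 2 to compound 3 (beyond the scatter).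

Compound 4 `O=C(CCCc1ccc(Cl)cn1)N1CCc2c(Cl)c(O)c(O)c(Cl)c2C1` has not yet been measured. It differs from compound 2 in one place: chloro in place of fluoro on an aromatic carbon. Among the compounds with values here, of the measured steps, only the one from compound 2 to compound 3 bears on this change, since it removes the same fluoro from the same aromatic carbon; that step was of modest size and ran downward. Here the group that enters counts one heavy atom, as the group that leaves does, so a smaller step in the same direction, near the edge of the scatter, is expected. The read-out of compound 4 is therefore expected at 82%, within a range from 70% to 92%. This estimate means an expected step of a number 7 percentage points lower from compound 2 to compound 4 (within the scatter).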

Compound 4, a percentage reported as activity, at one concentration (the size of the read-out at that concentration, not a potency): 85%
Compound 4: the middle estimate sits 3 percentage points below what was measured, and the stated range covers the measured number.
By their numbers in this assay, from the lowest: compound 3; then compounds 1, 4 and 2 (each within the scatter of the next).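

In this assay, chloro in place of fluoro at this position, on the aromatic carbon two atoms from the ring nitrogen and para to a large group, gives a number 4 percentage points lower from compound 2 to compound 4 (within the scatter), so exchanging one single-atom halogen for the other leaves the read-out without a clear change. Chloro in place of trifluoromethyl on the same carbon gives a number 13 percentage points higher from compound 3 to compound 4 (beyond the scatter), which shows that among the three groups compared here, trifluoromethyl alone separates from both others beyond the scatter, and that the earlier step from fluoro was not a shift shared by any replacement of that atom. Nothing measured here accounts for this difference between the groups.

From the compounds shown here alone, it remains open how a methoxy group, a nitrile or an amine on this same carbon would read, and so whether the separation belongs to trifluoromethyl alone or extends to other groups. Going by these compounds, it is also open whether trifluoromethyl would keep its separation from fluoro and chloro with a longer or shorter chain between the carbonyl and the aromatic ring.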